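The compounds below may be only part of what the source reports. "The series", "measured", "known", "first", "only" and "open" are said of these compounds alone.

Compound 2 `CC(C)CCn1c(Cn2c(=O)n(C(C)C)c3ccccc32)nc2cc(CNS(C)(=O)=O)ccc21` gives, in an ADME assay on HEp-2 cells (Homo sapiens) for cytotoxicity (a higher number here means that more compound is tolerated, a lower number that less compound is tolerated), a value of 30800 nM, numerically the top of the two numbers at hand. Compound 1 `C=C(C)n1c(=O)n(Cc2nc3ccccc3n2CCC(C)C)c2ccccc21` gives 24600 nM in this assay, and this gap lies within the usual scatter, so the two compounds cannot be told apart. Compound 3 `CC(C)CCn1c(Cn2c(=O)n(C(C)C)c3ccccc32)nc2cc(N)ccc21` has not been measured; it differs from compound 2 in one place: amino in place of (methanesulfonamido)methyl on an aromatic carbon. Going by the values given here, no measured pair with a single change is available to set the size of such a step, so nothing beyond the scatter is expected, and the step is estimated as a 1.2-fold lower number from compound 2 to compound 3 (0.09 log units; within the scatter). For compound 3 the expected result is 25000 nM, within a range from 8000 nM to 70000 nM.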

Compound 3, half-maximal cytotoxic concentration: 32200 nM
Estimate against measurement, compound 3: 1.3-fold (0.11 log units) below; the measured number falls inside the stated range.
By their numbers in this assay, from the lowest: compounds 1, 2 and 3 (each within the scatter of the next).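

In this assay putting amino in place of (methanesulfonamido)methyl gives a 1.0-fold higher number from compound 2 to compound 3 (0.02 log units; within the scatter) on this aromatic carbon. This single change removes a group of six heavy atoms and leaves one of a single heavy atom, yet the two numbers cannot be told apart, so in this pair the larger group makes no readable difference. Nothing at hand explains this result. From the compounds shown here alone, whether a carboxylic acid or a longer chain on this carbon would also leave the number within the scatter remains open. So does whether this one pair holds for other positions on the ring.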